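This account rests on a few compounds, and the source may have more. Where it says the series, first, only, none or still open, it means among the compounds named here.

The series shares one core, varied at a single aromatic carbon. Compound 1 `Cc1nn(-c2nc(-c3ccc(Cl)c(Cl)c3)c(SC(C)C)s2)c(C(=O)O)c1-c1cccc(F)c1` gives 900 nM in a functional assay on BJAB cells (Homo sapiens) for antiproliferative activity, with a stated time of 4 days; a lower number here means that less compound is needed, a higher number that more compound is needed for the effect. Compound 2 `Cc1cc(C)cc(-c2c(C)nn(-c3nc(-c4ccc(Cl)c(Cl)c4)c(SC(C)C)s3)c2C(=O)O)c1` gives 2700 nM in this assay, and compound 3 `Cc1nn(-c2nc(-c3ccc(Cl)c(Cl)c3)c(SC(C)C)s2)c(C(=O)O)c1-c1cnccn1` gives 14000 nM in this assay. Compound 2 stands second highest of the three numbers: a 3.0-fold higher number from compound 1 to compound 2 (0.48 log units; beyond the scatter), a 5.2-fold higher number from compound 2 to compound 3 (0.71 log units; beyond the scatter), and a 16-fold higher number from compound 1 to compound 3 (1.19 log units; beyond the scatter).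

Compound 4 `Cc1nn(-c2nc(-c3ccc(Cl)c(Cl)c3)c(SC(C)C)s2)c(C(=O)O)c1-c1ccc(C(F)(F)F)cc1` is not yet measured. Its change from compound 2 is 4-(trifluoromethyl)phenyl in place of 3,5-dimethylphenyl on an aromatic carbon. For the measured compounds named here, no measured step exchanges one substituted phenyl for a phenyl bearing trifluoromethyl; the nearest comparison is a 3.0-fold higher number from compound 1 to compound 2 (0.48 log units; beyond the scatter), a modest change between two substituted phenyl groups, while a 16-fold higher number from compound 1 to compound 3 (1.19 log units; beyond the scatter) and a 5.2-fold higher number from compound 2 to compound 3 (0.71 log units; beyond the scatter) concern a pyrazin-2-yl and are larger. Compound 4 keeps a six-membered aromatic ring of carbon only, so a step in this assay of at most modest size is expected in either direction, with a lower number somewhat more likely in view of compound 1 at 900 nM. The expected step is a 1.4-fold lower number from compound 2 to compound 4 (0.13 log units; within the scatter). Compound 4 is estimated at 2000 nM, between 600 nM and 7000 nM.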

Compound 4, half-maximal effective concentration: 3500 nM
Compound 4: the middle estimate sits 1.8-fold (0.24 log units) below what was measured; the range from low to high includes it.
By their numbers in this assay, from the lowest: compound 1; then compounds 2 and 4 (each within the scatter of the next); then compound 3.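

In this assay, the result gives 4-(trifluoromethyl)phenyl and 3,5-dimethylphenyl no separable difference at this position, with a 1.3-fold higher number from compound 2 to compound 4 (0.11 log units; within the scatter), so these two different substitution patterns on a carbon-only aromatic ring cannot be told apart. Against the remaining two groups, a 3.9-fold higher number from compound 1 to compound 4 (0.59 log units; beyond the scatter) keeps 3-fluorophenyl at the low end of the series, and a 4.0-fold lower number from compound 3 to compound 4 (0.60 log units; beyond the scatter) keeps pyrazin-2-yl at the high end, now against a third carbon-only aromatic ring. Nothing available explains these differences.

Open, on these data alone, is whether the lower number of compound 1 depends on the fluorine itself or on where it sits on the phenyl, and how an unsubstituted phenyl would compare. Also open, as far as these compounds go, is how a phenyl carrying an amine or a carboxylic acid would compare at this position.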